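A Second Chloro Enters the Ring of Compound 2

A few compounds are considered here, and "the series" means these few. Any claim that something is new, unique, unknown or untested is made for them only; others in the source may bear on it.

Compound 2 `Cn1nc(CN2CCCC2)nc1-c1ccc(Cl)cc1` gives in an assay on membranes from Jurkat cells for displacement of a labelled ligand from Sigma intracellular receptor 2 (Homo sapiens), read by scintillation counting, with a stated time of 1 h (on this read-out higher numbers stand for weaker inhibition and lower numbers for stronger inhibition), only a limit, > 1000 nM, and not a number. The two companions measured beside it share its core and differ from it at a single group on the six-membered aromatic ring of carbon only: compound 1 `Cn1nc(CN2CCCC2)nc1-c1ccc(C2CC2)cc1` gives 1000 nM, and compound 3 `CC(C)c1ccc(-c2nc(CN3CCCC3)nn2C)cc1` gives 1000 nM. The step of no change at the digits printed from compound 1 to compound 3 (within the scatter) lies within the scatter, whereas a number no lower from compound 1 to compound 2 (the limit leaves the size open) and a number no higher from compound 2 to compound 3 (the limit leaves the size open) are open in size because compound 2 sits at the limit of > 1000 nM in this assay, at which 1 of the 3 values shown sits.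

Compound 4 `Cn1nc(CN2CCCC2)nc1-c1ccc(Cl)c(Cl)c1` differs from compound 2 by chloro in place of hydrogen on an aromatic carbon. Among the compounds with values here, none of the three measured steps changes this place; each of them swaps the group that compound 1, compound 2 and compound 3 carry in common, so no measured step bears directly on the new chloro. With nothing pointing either way, a step beyond the scatter is not expected. The expected step is a step that the limit leaves unreadable from compound 2 to compound 4. Compound 4 is therefore estimated at 1500 nM, with a range from 500 nM to 5000 nM, and a reported limit in this assay remains quite possible.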

Compound 4, inhibition constant: > 1000 nM
Compound 4 gave a limit, no number (the forecaster's own chance of this, stated with the estimate: 60%); the middle value lies beyond the limit too.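

In this assay compound 4 gives > 1000 nM, a limit and not a number, and compound 2 also gives only a limit, so no step can be read between them: the limit of > 1000 nM in this assay, at which 2 of the 4 values shown sit.

As far as these compounds go, whether the added chloro changes inhibition at all, and how far compound 2 and compound 4 lie from compound 1 and compound 3, stays open.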